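From chloro to hydroxy on the shared core

A few compounds are considered here, and "the series" means these few. Any claim that something is new, unique, unknown or untested is made for them only; others in the source may bear on it.

Compound 1 `COc1ccc(C2=C(c3cc(OC)c(OC)c(OC)c3)C(=O)C(OC(C)=O)C2)cc1F`: 59 ug/mL
Compound 2 `COc1ccc(C2=C(c3cc(OC)c(OC)c(OC)c3)C(=O)C(OC(C)=O)C2)cc1Cl`: 60 ug/mL

These two values come from an ADME assay on HEK293 cells (Homo sapiens) for cytotoxicity, read by MTT assay, with a stated time of 72 h; a lower number here means a stronger inhibitor, a higher number a weaker inhibitor. There, compound 2 gives 60 ug/mL, which lies within the scatter of the number for compound 1, so the pair stands level. The next compound to be measured is compound 3 `COc1ccc(C2=C(c3cc(OC)c(OC)c(OC)c3)C(=O)C(OC(C)=O)C2)cc1O`. The change from compound 2 is hydroxy in place of chloro on an aromatic carbon, with hydroxy in place of chloro on an aromatic carbon, ortho to a methoxy group. Among the measured compounds shown here, only one measured step bears on this: a 1.0-fold higher number from compound 1 to compound 2 (0.01 log units; within the scatter), with chloro in place of fluoro. That step stays within the scatter, but it does not cover a hydroxy group, so the data give no direction. No step beyond the scatter is therefore expected in this assay, though with little certainty. The expected change is a 1.2-fold lower number from compound 2 to compound 3 (0.08 log units; within the scatter). Compound 3 is estimated at 50 ug/mL, with an expected range from 20 ug/mL to 90 ug/mL.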

Compound 3, half-maximal inhibitory concentration: 92 ug/mL
Compound 3: the middle estimate sits 1.8-fold (0.26 log units) below what was measured; the whole stated range lies below it.
By their numbers in this assay, from the lowest: compounds 1, 2 and 3 (each within the scatter of the next).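

Replacing chloro with hydroxy, ortho to a methoxy group, brings in a hydrogen-bond donor and a hydrogen-bond acceptor, yet this assay gives a 1.5-fold higher number from compound 2 to compound 3 (0.19 log units; within the scatter) as the reading for this change. Set against the fluoro group, the same position gives a 1.6-fold higher number from compound 1 to compound 3 (0.19 log units; within the scatter) as its reading, so fluoro, chloro and hydroxy all stand level here, and the level reading now extends to a group that differs from chloro in its donor and acceptor counts. Nothing measured here offers an explanation for this reading.

On these data alone, whether an amine, a carboxylic acid or a longer chain on this aromatic carbon would produce a step beyond the scatter remains open. So does whether a change elsewhere on the shared core would separate these compounds.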